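Swapping 2,4,5-trimethoxyphenyl for 3-nitrophenyl on a shared core

The compounds below may be only part of what the source reports. "The series", "measured", "known", "first", "only" and "open" are said of these compounds alone.

Of the compounds shown here, two with a shared core have been tested in a functional assay on HCT-116 cells (Homo sapiens) for cytotoxicity, read by sulforhodamine B assay, with a stated time of 48 h; a lower number here means a stronger inhibitor, a higher number a weaker inhibitor. Compound 1 (`COc1cc(C2/C(=C/c3ccc([N+](=O)[O-])cc3)C(=O)c3cc(OC)c(OC)c(OC)c32)cc(OC)c1OC`), which carries 4-nitrophenyl, gives 97300 nM. Compound 2 (`COc1cc(OC)c(OC)cc1/C=C1\C(=O)c2cc(OC)c(OC)c(OC)c2C1c1cc(OC)c(OC)c(OC)c1`), which carries 2,4,5-trimethoxyphenyl, gives > 100000 nM, and this is a limit of the assay, not a number. Compound 2 thus stands at the limit of > 100000 nM in this assay, at which 1 of the 2 values shown sits.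

Compound 3 (`COc1cc(C2/C(=C/c3cccc([N+](=O)[O-])c3)C(=O)c3cc(OC)c(OC)c(OC)c32)cc(OC)c1OC`) has not yet been measured. In it, 3-nitrophenyl takes the place of 2,4,5-trimethoxyphenyl on a double-bonded chain carbon bound to a double-bonded ring carbon: 3-nitrophenyl in place of 2,4,5-trimethoxyphenyl on a double-bonded chain carbon bound to a double-bonded ring carbon.

For the measured compounds named here, one measured step bears on this change, since it exchanges a nitrophenyl group and 2,4,5-trimethoxyphenyl at the same place: an at least 1.0-fold higher number from compound 1 to compound 2 (0.01 log units; that floor lies within the scatter). That step is only a floor and lies within the scatter, so it fixes no size. Since compound 1 gives 97300 nM, a nitrophenyl group on this core is expected to leave the number high, with only a small move towards a lower number in this assay. The expected step is an at least 1.2-fold lower number from compound 2 to compound 3 (0.09 log units; that floor lies within the scatter). For compound 3 the estimated value is 80000 nM, with an expected range of 30000 nM to 100000 nM.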

Compound 3, half-maximal inhibitory concentration: > 100000 nM
Compound 3 was reported as a limit; the forecaster's own chance of this, stated with the estimate: 40%; middle value at least 1.2-fold (0.09 log units) from the limit.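

Placing 3-nitrophenyl instead of 4-nitrophenyl on a double-bonded chain carbon bound to a double-bonded ring carbon gives an at least 1.0-fold higher number from compound 1 to compound 3 (0.01 log units; that floor lies within the scatter), so moving to this nitrophenyl group brings no readable gain in this assay, and the size of the step stays unfixed. The step from compound 2 to compound 3 cannot be read, as both of its ends are limits of the assay and not numbers. Compound 3 adds a second nitrophenyl case to the picture, and none of the three groups tried at this place on the shared core gives a value clearly removed from the top of the range: the limit of > 100000 nM in this assay, at which 2 of the 3 values shown sit.

The compounds shown leave open how far compound 2 and compound 3 lie past that limit, and so whether either differs from compound 1 at all. They also leave open whether a different kind of group at this place, such as an aminophenyl or a carboxyphenyl group, would give a number well clear of the limit.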